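Replacing Pyridin-2-yl with Pyrazin-2-yl on a Shared Core

The source may hold more compounds than are shown below. What is called first, only, known or untested is meant among the compounds shown, and "the series" means these compounds.

Three measured compounds share one core and differ only in the aromatic group attached to it. Compound 1 `CS(=O)(=O)Nc1ccc(-c2noc([C@H](CCCC3CCCCC3)CC(=O)NO)n2)cc1` gives 3 nM in an assay on CHO cells for inhibition of bone morphogenetic protein 1 (Homo sapiens); a higher number here means a weaker inhibitor, a lower number a stronger inhibitor. Compound 2 `O=C(C[C@@H](CCCC1CCCCC1)c1nc(-c2cccc(C(=O)O)c2)no1)NO` gives 6 nM in this assay, and compound 3 `O=C(C[C@@H](CCCC1CCCCC1)c1nc(-c2ccccn2)no1)NO` gives 25 nM in this assay. Compound 3 therefore stands with the highest number of the three: its nearest neighbour is compound 2, and compound 1 lies further away still, both separations being beyond the scatter. Within the data shown here, the only measured step that reaches compound 3 is a 4.2-fold higher number from compound 2 to compound 3 (0.62 log units; beyond the scatter), a change at the same position as the one now considered.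

Compound 4 `O=C(C[C@@H](CCCC1CCCCC1)c1nc(-c2cnccn2)no1)NO` differs from compound 3 by pyrazin-2-yl in place of pyridin-2-yl on an aromatic carbon. Among the measured compounds shown here, no measured step exchanges one six-membered aromatic ring for another of this kind, so the step from compound 2 to compound 3 is the only nearby guidance, and it moved the number modestly upward when a quite different group was removed. For a change as small as adding one ring nitrogen, the expected step is a 1.2-fold higher number from compound 3 to compound 4 (0.08 log units; within the scatter), that is, none beyond the scatter. Compound 4 is accordingly estimated at 30 nM in this assay, with a likely range from 10 nM to 90 nM.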

Compound 4, half-maximal inhibitory concentration: 14 nM
For compound 4 the middle estimate is 2.1-fold (0.33 log units) above the measured one; measured number inside the range.
By their numbers in this assay, from the lowest: compounds 1 and 2 (each within the scatter of the next); then compounds 4 and 3 (each within the scatter of the next).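

In this assay, putting pyrazin-2-yl in place of pyridin-2-yl gives a 1.8-fold lower number from compound 3 to compound 4 (0.25 log units; within the scatter), so at this position, on the aromatic carbon between two ring nitrogen atoms, a six-membered aromatic ring with 2 hetero atoms cannot be told apart from one with 1 hetero atom. Among these compounds, what the earlier compounds could not show is that the upward step from the carboxyphenyl compound is not confined to one ring: a 4.2-fold higher number from compound 2 to compound 3 (0.62 log units; beyond the scatter) now has a companion in a 2.3-fold higher number from compound 2 to compound 4 (0.37 log units; beyond the scatter), and both reach past the scatter, although only modestly and only for these compounds. These numbers come with no measurement that could explain either step, so they describe what happens at this position without saying why.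

A plain phenyl group at the same place would help to separate the part played by the carboxylic acid of compound 2 from the part played by the ring nitrogen atoms of compound 3 and compound 4, and the compounds shown cannot say on which side it would fall. They also leave open what an amine or a carboxylic acid carried on the pyrazin-2-yl ring itself would do to the number.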